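From 4-ethylcyclohexyl to 2-cyclohexylethyl on a shared core

A few compounds are considered here, and "the series" means these few. Any claim that something is new, unique, unknown or untested is made for them only; others in the source may bear on it.

In a physicochemical assay for solubility, read by nephelometry, measured as kinetic solubility (a higher number here means a more soluble compound, a lower number a less soluble compound), compound 1 `CC(=O)Nc1cnc2[nH]c(=O)n([C@H]3CC[C@H](C(C)(C)C)CC3)c(=O)c2c1` gives 310000 nM, compound 2 `CC(=O)Nc1cnc2[nH]c(=O)n([C@H]3CC[C@@H](C(C)C)CC3)c(=O)c2c1` gives 15000 nM and compound 3 `CC[C@H]1CC[C@H](n2c(=O)[nH]c3ncc(NC(C)=O)cc3c2=O)CC1` gives 22000 nM. Compound 3 sits level with compound 2, within the scatter, and well under compound 1. Compound 4 `CC(=O)Nc1cnc2[nH]c(=O)n(CCC3CCCCC3)c(=O)c2c1` carries 2-cyclohexylethyl in place of 4-ethylcyclohexyl on an aromatic nitrogen: the same atoms, joined differently. Within the data shown here, the one measured step, a 14-fold lower number from compound 1 to compound 3 (1.15 log units; beyond the scatter), is large, but it put ethyl in place of tert-butyl on a saturated ring carbon, a different kind of change, so it gives no direction here. No clear move in this assay is therefore expected, though uncertainty stays wide. The expected step is a 1.1-fold lower number from compound 3 to compound 4 (0.04 log units; within the scatter). For compound 4 the estimate is 20000 nM, with an expected range from 6000 nM to 70000 nM.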

Compound 4, solubility: 97000 nM
Compound 4: middle estimate off by 4.9-fold (0.69 log units), on the low side, and the stated range ends below it.
By their numbers in this assay, from the lowest: compounds 2 and 3 (each within the scatter of the next); then compound 4; then compound 1.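

In this assay, rearranging the same carbons from 4-ethylcyclohexyl to 2-cyclohexylethyl on the aromatic nitrogen gives a 4.4-fold higher number from compound 3 to compound 4 (0.64 log units; beyond the scatter), a step beyond the scatter. At this position, then, how the atoms are joined can shift the number even though no atom is added or lost, and the 2 defined stereocentres of the leaving group are gone. The earlier compounds shown here all kept the ring directly on the nitrogen and varied only its alkyl group. Going by these compounds, whether a longer chain to the cyclohexyl ring, or an amine on that ring, would shift the number further remains open. Nothing measured here explains this step.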